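Trimming an ester chain: dihydropyrimidinones at the adenosine receptor

A few compounds are considered here, and "the series" means these few. Any claim that something is new, unique, unknown or untested is made for them only; others in the source may bear on it.

Three dihydropyrimidinones were tested in an assay on membranes from CHO cells for displacement of a labelled ligand from adenosine receptor A1 (Homo sapiens), read by scintillation counting, with a stated time of 60 min, tested at 1 uM; a lower number here means less inhibition, a higher number more inhibition at the concentration tested (going by the name of the read-out). Compound 1 `CCNC(=O)C1=C(C)NC(=O)NC1c1ccsc1` gives 3%, compound 2 `CC1=C(C(=O)NC(C)C)C(c2ccsc2)NC(=O)N1` gives 8%, and compound 3 `CCC(CC)OC(=O)C1=C(C)NC(=O)NC1c1ccoc1` gives 17%. The difference between the core of compound 2 and the core of compound 3 is not broken down here. From compound 2 to compound 1 the change is hydrogen in place of methyl on a saturated chain carbon bound to an amide-type nitrogen and a saturated chain carbon; this gave a number 5 percentage points lower from compound 2 to compound 1 (within the scatter). Compound 4 `CCC(C)OC(=O)C1=C(C)NC(=O)NC1c1ccoc1` has not yet been measured in this assay. From compound 3 to compound 4 the change is hydrogen in place of methyl on a saturated chain carbon, two bonds along the chain from an oxygen next to a carbonyl group, the same kind of change, though here the place is two bonds along the chain from an oxygen next to a carbonyl group rather than bound to an amide-type nitrogen. Because a number 5 percentage points lower from compound 2 to compound 1 (within the scatter) stayed within the scatter, compound 4 is expected to sit near compound 3, at an estimated 13%, between 2% and 26%. This estimate means an expected step of a number 4 percentage points lower from compound 3 to compound 4 (within the scatter).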

Compound 4, a percentage reported as inhibition, at one concentration (the size of the read-out at that concentration, not a potency): 13%
Beside the measured number, compound 4's estimate shows no gap at the digits printed, and the stated range covers the measured number.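

In this assay, hydrogen in place of methyl on a saturated chain carbon, two bonds along the chain from an oxygen next to a carbonyl group, turning pentan-3-yl into sec-butyl, gave a number 4 percentage points lower from compound 3 to compound 4 (within the scatter). Set beside the same change at the other place, on the other core, the two steps agree: the same change on two cores in this assay, a number 5 percentage points lower (within the scatter) from compound 2 to compound 1 and a number 4 percentage points lower (within the scatter) from compound 3 to compound 4, 1 percentage points apart, within the scatter of two such steps. For the compounds shown here, this shows that removing the methyl moved the reading little on either core, but it does not show a real effect that carries over, since neither step stands clear of the scatter and only two cores are compared.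

The compounds shown leave open what a longer chain would do at this place. They also leave open how a carboxylic acid or an amine in place of the ester would read in this assay.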